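The source may report more compounds than this note shows. Statements on the series, on what has been measured and on what is new or still open speak of the compounds shown alone.

Compound 1 `c1ccc(Oc2ccc(-c3noc(-c4ccc(C5=NCCN5)cc4)n3)cc2)cc1` gives 2770 nM in an assay for inhibition of Amine oxidase [flavin-containing] A (Homo sapiens), read by fluorescence and spectrophotometry, using microsomes, with stated times of 30 min and 20 min; a higher number here means a weaker inhibitor, a lower number a stronger inhibitor. Compound 2 `c1ncn(Cc2ccc(-c3noc(-c4ccc(C5=NCCN5)cc4)n3)cc2)n1` gives 24600 nM.

Among the compounds with values here, compound 2 stands highest of the two numbers measured so far; its nearest neighbour is compound 1, which lies an 8.9-fold higher number from compound 1 to compound 2 (0.95 log units; beyond the scatter) away in the other direction. Compound 3 `c1ccc(-c2ccc(-c3noc(-c4ccc(C5=NCCN5)cc4)n3)cc2)cc1` has not yet been measured. It differs from compound 2 in one place: phenyl in place of (1H-1,2,4-triazol-1-yl)methyl on an aromatic carbon. Within the data shown here, the only measured step that bears on this is the one from compound 1 to compound 2, which gave an 8.9-fold higher number from compound 1 to compound 2 (0.95 log units; beyond the scatter) when phenoxy was exchanged for (1H-1,2,4-triazol-1-yl)methyl. Since phenyl resembles phenoxy more closely than it resembles the triazolylmethyl group, a return toward the lower number of compound 1 is expected, a 7.0-fold lower number from compound 2 to compound 3 (0.85 log units; beyond the scatter). Compound 3 is therefore estimated at 3500 nM, within 1000 nM to 12000 nM.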

Compound 3, half-maximal inhibitory concentration: > 100000 nM
Compound 3: a limit, no number; the forecaster's own chance of this, stated with the estimate: 5%; middle value at least 28-fold (1.45 log units) away from the limit.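

The value of compound 3 is a limit of the assay, not a number: the limit of > 100000 nM in this assay, at which 1 of the 3 values shown sits.

Phenyl on this aromatic carbon, para to a large group, gives an at least 4.0-fold higher number from compound 2 to compound 3 (0.60 log units; beyond the scatter), so replacing the triazole-bearing group with a carbon-only aromatic ring does not restore the activity of compound 1. Against phenoxy, the same group gives an at least 36-fold higher number from compound 1 to compound 3 (1.55 log units; beyond the scatter), so this position separates two groups that differ only by the oxygen atom joining the outer ring.

Going by these compounds, whether another joined ring, such as benzyl, would behave like phenoxy remains open. So does the effect of a small amine or a carboxylic acid here.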